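Compound 3 to compound 4: fluoro for trifluoromethyl

A few compounds are considered here, and "the series" means these few. Any claim that something is new, unique, unknown or untested is made for them only; others in the source may bear on it.

In an ADME assay on Vero cells (Chlorocebus sabaeus) for cytotoxicity, with a stated time of 72 h (a higher number here means a weaker inhibitor, a lower number a stronger inhibitor), compound 1 `O=C(CCN1CCN(c2ccc(C(F)(F)F)cc2)CC1)c1csc2ccccc12` gives 237000 nM and compound 2 `O=C(CCN1CCN(c2ccc(C(F)(F)F)cc2)CC1)c1csc2ccc(F)cc12` gives 896000 nM while compound 3 `O=C(CCN1CCN(c2ccc(C(F)(F)F)cc2)CC1)c1ccc2ccccc2c1` gives 30100 nM and so holds the lowest number of the three. That position rests on a 7.9-fold lower number from compound 1 to compound 3 (0.90 log units; beyond the scatter) and a 30-fold lower number from compound 2 to compound 3 (1.47 log units; beyond the scatter) and both steps lie beyond the scatter.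

Compound 4 `O=C(CCN1CCN(c2ccc(F)cc2)CC1)c1ccc2ccccc2c1` keeps the naphthalen-2-yl group of compound 3 and differs from it in one place: fluoro in place of trifluoromethyl on an aromatic carbon (fluoro in place of trifluoromethyl on an aromatic carbon, para to a large group). Going by the values given here, no measured step changes this group; all three concern the group on the carbonyl carbon. The closest guide is a 3.8-fold higher number from compound 1 to compound 2 (0.58 log units; beyond the scatter) for fluoro in place of hydrogen on an aromatic carbon elsewhere in the molecule, a modest step toward a higher number, and it is only a loose guide. Steps in the series run from modest to large, so a modest step in this assay toward a higher number is expected, though one within the scatter cannot be ruled out. Compound 4 is estimated at 60000 nM with a range from 20000 nM to 180000 nM as the expected span. That estimate amounts to a 2.0-fold higher number from compound 3 to compound 4 (0.30 log units; within the scatter) as the expected step.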

Compound 4, half-maximal inhibitory concentration: 103000 nM
Compound 4: the middle estimate sits 1.7-fold (0.23 log units) below what was measured; low and high end bracket the measured number.
By their numbers in this assay, from the lowest: compound 3; then compound 4; then compound 1; then compound 2.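

The change from 4-(trifluoromethyl)phenyl to 4-fluorophenyl gives a 3.4-fold higher number from compound 3 to compound 4 (0.53 log units; beyond the scatter) in this assay. This shows that the aromatic ring carrying the trifluoromethyl group, unchanged across compound 1, compound 2 and compound 3, also moves the number beyond the scatter, so the group on the carbonyl carbon is not the only place in the series that matters for this read-out. Going by these compounds alone, the step points the same way as a 3.8-fold higher number from compound 1 to compound 2 (0.58 log units; beyond the scatter), although these are only two steps, with different changes at different places on different parent compounds, and no data on hand bear on why the number rises at this position.

Within the data shown here, whether the same change would give a step of similar size with 1-benzothiophen-3-yl on the carbonyl carbon remains open, since compound 3 and compound 4 provide the only reading of this position. Also open, as far as these compounds go, is how this aromatic carbon would read with hydrogen, chloro, methoxy or a carboxylic acid in place of fluoro or trifluoromethyl, which would show whether the two values shown belong to a wider trend.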